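Working notes: from compound 1 to compound 3

The source may report more compounds than this note shows. Statements on the series, on what has been measured and on what is new or still open speak of the compounds shown alone.

Measured so far in a functional assay on OVCAR-3 cells (Homo sapiens) for antiproliferative activity, read by MTT assay, with a stated time of 24 h; on this read-out lower numbers stand for stronger inhibition and higher numbers for weaker inhibition:
- Compound 1 `O=C(NNc1ccccc1Cl)c1ccccc1NS(=O)(=O)c1cnc(O)nc1O` gives 14100 nM
- Compound 2 `CCCCOc1ccc(C(=O)NNC(=O)c2ccc(NS(=O)(=O)c3cnc(O)nc3O)cc2)cc1` gives 12800 nM

Compound 1 and compound 2 lie within the scatter of each other, so neither stands apart on these numbers. Among the measured compounds shown here, no measured pair differs in one place.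

Compound 3 `O=C(NNC(=O)c1ccccc1NS(=O)(=O)c1cnc(O)nc1O)c1ccccc1Cl` is the next entry. Compared with compound 1, it carries (2-chlorophenyl)carbonyl in place of 2-chlorophenyl on an amine nitrogen and is otherwise unchanged.

For the measured compounds named here, no measured step shows what this change does in this assay, so the expectation rests only on the two close values. No step beyond the scatter is expected, and no firm direction can be given. The estimated change is small, a 1.1-fold lower number from compound 1 to compound 3 (0.04 log units; within the scatter), and stays within the scatter. For compound 3 the estimate is 13000 nM, with an expected range from 5000 nM to 32000 nM.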

Compound 3, half-maximal inhibitory concentration: 18200 nM
Beside the measured number, compound 3's estimate is 1.4-fold (0.15 log units) below it; measured number inside the range.
By their numbers in this assay, from the lowest: compounds 2, 1 and 3 (each within the scatter of the next).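

In this assay, among the compounds shown here, the only step so far that changes one place reads a 1.3-fold higher number from compound 1 to compound 3 (0.11 log units; within the scatter) and stays within the scatter. On an amine nitrogen whose other neighbour is an amide-type nitrogen, (2-chlorophenyl)carbonyl in place of 2-chlorophenyl therefore gives no read-out distinct from compound 1, even though the entering group adds a carbonyl and a hydrogen-bond acceptor. No supporting measurement is available to interpret this result.

Compound 2 differs from compound 1 and compound 3 in more than one place, so it cannot show whether this tolerance extends to other groups. The compounds shown leave open whether a group without the aromatic ring at this place, such as acetyl, or a group carrying an amine or a carboxylic acid, would give a step beyond the scatter.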